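A few compounds are considered here, and "the series" means these few. Any claim that something is new, unique, unknown or untested is made for them only; others in the source may bear on it.

In a functional assay on MIA PaCa-2 cells (Homo sapiens) for inhibition, read by MTT assay, with a stated time of 3 days (on this read-out lower numbers stand for stronger inhibition and higher numbers for weaker inhibition), two related compounds have been tested so far: compound 1 (`O=C([C@@H]1CCCN(S(=O)(=O)c2ccc(S(=O)(=O)C3CCC3)cc2)C1)N1CCC(F)(F)CC1`) and compound 2 (`CCN(CC)S(=O)(=O)c1ccc(S(=O)(=O)N2CCC[C@@H](C(=O)N[C@H]3CCOC3)C2)cc1`). Compound 1 gives > 3000 nM, which is a limit of the assay and not a number. Compound 2 gives > 10000 nM, which is also a limit, so compound 2 has no exact potency to serve as a starting point.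

Compound 3 (`CCN(CC)S(=O)(=O)c1ccc(S(=O)(=O)N2CCC[C@@H](C(=O)N3CC[C@@H](OC)C3)C2)cc1`) keeps the core of compound 2 and changes one group: 3-methoxypyrrolidin-1-yl in place of (oxolan-3-yl)amino on a carbonyl carbon. Here, 3-methoxypyrrolidin-1-yl takes the place of (oxolan-3-yl)amino on a carbonyl carbon, and each group has one five-membered non-aromatic ring with 1 hetero atom.

Among the compounds with values here, no measured pair shows what this change does in this assay, so no shift beyond the usual scatter is expected. The estimated step of a number no higher from compound 2 to compound 3 (the limit leaves the size open) reflects that expectation. For compound 3, the expected value is 10000 nM, within an estimated range of 3000 nM to 30000 nM.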

Compound 3, half-maximal inhibitory concentration: > 10000 nM
Compound 3: only a limit was reported (the forecaster's own chance of this, stated with the estimate: 75%); the middle value lies on the limit itself.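

In this assay compound 3 gives > 10000 nM, which is a limit and not a number. Compound 2 also stands at a limit, so no step can be read from the pair. The compounds shown leave open whether 3-methoxypyrrolidin-1-yl and (oxolan-3-yl)amino differ in effect at all.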